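The source may report more compounds than this note shows. Statements on the series, on what has been measured and on what is new or still open speak of the compounds shown alone.

Compound 1, `CCCS(=O)(=O)Nc1ccc(F)c(C(=O)c2n[nH]c3ncc(-c4ccc(OC)cc4)cc23)c1F`: 4.2%
Compound 2, `CCCS(=O)(=O)Nc1ccc(F)c(C(=O)c2n[nH]c3ncc(-c4ccc(N(C)C)cc4)cc23)c1F`: 2.5%
Compound 3, `CCCS(=O)(=O)Nc1ccc(F)c(C(=O)c2n[nH]c3ncc(-c4cc(Cl)cc(Cl)c4)cc23)c1F`: 73%

These three compounds share one core and differ only in the aromatic group attached to it. In an assay for binding affinity to dual specificity mitogen-activated protein kinase kinase 4 (Homo sapiens), read by KINOMEscan, tested at 100 nM (on this read-out lower numbers stand for a stronger effect and higher numbers for a weaker effect at the one concentration tested), compound 3 gives the highest number of the three and stands far apart from the other two, as the steps of a number 68.8 percentage points higher from compound 1 to compound 3 (beyond the scatter) and a number 70.5 percentage points higher from compound 2 to compound 3 (beyond the scatter) show; the step of a number 1.7 percentage points lower from compound 1 to compound 2 (within the scatter), by contrast, is within the scatter. Compound 4, `CCCS(=O)(=O)Nc1ccc(F)c(C(=O)c2n[nH]c3ncc(-c4ccc(C(=O)O)cc4)cc23)c1F`, has not yet been measured. It differs from compound 3 in one place: 4-carboxyphenyl in place of 3,5-dichlorophenyl on an aromatic carbon. Within the data shown here, no measured step swaps exactly these two groups. Among the measured compounds shown here, the two large steps that lead to compound 3 both start from a phenyl bearing a single group, much like the 4-carboxyphenyl entering compound 4, and both run upward; reversing that kind of change points downward, so a downward step is expected for compound 4, though a carboxyl group has no measured counterpart here and the size is uncertain. The expected step is a number 53 percentage points lower from compound 3 to compound 4 (beyond the scatter). Compound 4 is therefore estimated at 20%, with a range from 3% to 75%.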

Compound 4, a percentage reported as activity, at one concentration (the size of the read-out at that concentration, not a potency): 0.1%
The estimate for compound 4 lay 19.9 percentage points above the measured number; measured number outside the range, below it.
By their numbers in this assay, from the lowest: compounds 4, 2 and 1 (each within the scatter of the next); then compound 3.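

In this assay, 4-carboxyphenyl in place of 3,5-dichlorophenyl gives a number 72.9 percentage points lower from compound 3 to compound 4 (beyond the scatter), so this position of the shared core can carry a carboxy-bearing phenyl without the high number seen for compound 3. The carboxy group also cannot be told apart from the two earlier single groups, with a number 2.4 percentage points lower from compound 2 to compound 4 (within the scatter) and a number 4.1 percentage points lower from compound 1 to compound 4 (within the scatter); among the compounds shown, all three phenyls bearing one group give low numbers, and the dichlorinated compound 3 alone stands apart. No measured information here gives a reason for this gap.

Compound 3 differs from the others in both the kind of group and where the groups sit on the phenyl, so these two changes cannot be separated. A 4-chlorophenyl group, or a phenyl with a single methoxy group at its 3-position, would help to pull them apart.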